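Extending the Sulfonyl Chain of Compound 3

The source may report more compounds than this note shows. Statements on the series, on what has been measured and on what is new or still open speak of the compounds shown alone.

In a physicochemical assay for lipophilicity (a lower number here means a more polar compound, a higher number a more lipophilic compound), compound 3 `CCCCS(=O)(=O)c1ccc(O)c(C(=O)Nc2ccc(C(F)(F)F)cc2)c1` gives 4.14 and matches, within the scatter, compound 2 `CCCCS(=O)(=O)c1ccc(O)c(C(=O)Nc2ccc(Br)cc2)c1` at 4.12 while lying well under compound 1 `CCCCCCS(=O)(=O)c1ccc(O)c(C(=O)Nc2ccc(Br)cc2)c1` at 5.2 on the same scale. Going by the values given here, compound 4 `CCCCCCCCS(=O)(=O)c1ccc(O)c(C(=O)Nc2ccc(C(F)(F)F)cc2)c1` has butyl in place of hydrogen on a saturated chain carbon, four bonds along the chain from a sulfonyl sulfur as its one change, butyl in place of hydrogen on a saturated chain carbon, four bonds along the chain from a sulfonyl sulfur. Among the compounds with values here, the closest precedent runs the opposite way at that place, with hydrogen in place of ethyl, and shows a number 1.08 log units lower from compound 1 to compound 2 (beyond the scatter) as its large step. The change on the aromatic carbon gave only a number 0.02 log units higher from compound 2 to compound 3 (within the scatter) and offers no guide here. With butyl entering rather than ethyl leaving, a large upward step is expected, estimated as a number 2.06 log units higher from compound 3 to compound 4 (beyond the scatter) in all. Compound 4 is estimated at 6.2 with an expected range from 5.6 to 6.8 as the likely span.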

Compound 4, partition coefficient: 6.3
Estimate against measurement, compound 4: 0.10 log units below; the range from low to high includes it.
By their numbers in this assay, from the lowest: compounds 2 and 3 (each within the scatter of the next); then compound 1; then compound 4.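

In this assay the saturated chain carbon, four bonds along the chain from a sulfonyl sulfur, now gives an upward step, a number 2.16 log units higher from compound 3 to compound 4 (beyond the scatter) with butyl in place of hydrogen. Earlier, that place had shown only a downward step, a number 1.08 log units lower from compound 1 to compound 2 (beyond the scatter) on the bromo compounds. The number at this place therefore moves in both directions, and no compound shown goes against that. Nothing available accounts for the size of the new step. As far as these compounds go, whether a longer chain would raise the number further remains open, as does what an amine or a carboxylic acid in place of butyl would give.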